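A few compounds are considered here, and "the series" means these few. Any claim that something is new, unique, unknown or untested is made for them only; others in the source may bear on it.

Measured so far:
Compound 1 `COc1cc(-c2cc(COCc3cn(Cc4cc(-c5ccc(C)cc5)cnc4Cl)nn3)on2)cc(OC)c1OC`: 37300 nM
Compound 2 `COc1cc(C2CC(COCc3cn(Cc4cc(-c5ccc(F)cc5)cnc4Cl)nn3)ON2C=O)cc(OC)c1OC`: 32800 nM
Compound 3 `COc1cc(COCc2cn(Cc3cc(-c4ccccc4)cnc3Cl)nn2)cc(OC)c1OC`: 45500 nM

In a functional assay on DU-145 cells (Homo sapiens) for cytotoxicity, read by MTT assay, with a stated time of 48 h (a lower number here means a stronger inhibitor, a higher number a weaker inhibitor), compound 1 gives 37300 nM, which stands level, within the scatter, with the values of compound 2 and compound 3. Compound 4 `COc1cc(-c2cc(COCc3cn(Cc4cc(-c5ccc(F)cc5)cnc4Cl)nn3)on2)cc(OC)c1OC` has not yet been measured. It differs from compound 1 by fluoro in place of methyl on an aromatic carbon, para to a large group, so 4-methylphenyl becomes 4-fluorophenyl. Compound 2 carries 4-fluorophenyl on an altered core and gives 32800 nM, so no change beyond the scatter is expected in this assay. The expected size of the change is a 1.1-fold lower number from compound 1 to compound 4 (0.03 log units; within the scatter). The estimate for compound 4 is 35000 nM, with an expected range from 16000 nM to 75000 nM.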

Compound 4, half-maximal inhibitory concentration: 31900 nM
Beside the measured number, compound 4's estimate is 1.1-fold (0.04 log units) above it; the range from low to high includes it.
By their numbers in this assay, from the lowest: compounds 4, 2, 1 and 3 (each within the scatter of the next).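

In this assay, replacing 4-methylphenyl with 4-fluorophenyl on the shared core gives a 1.2-fold lower number from compound 1 to compound 4 (0.07 log units; within the scatter), so methyl and fluoro on this aromatic carbon cannot be told apart here. Among these compounds, this is the only direct reading of the position, as compound 2 and compound 3 each differ from compound 1 in more than one place. Nothing available explains this result. As far as these compounds go, whether an amine, a carboxylic acid or a longer chain such as butyl at the same place would move the number beyond the scatter remains open.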